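The source may hold more compounds than are shown below. What is called first, only, known or untested is meant among the compounds shown, and "the series" means these compounds.

Compound 1 `COc1ccc(C(=O)/C=C/c2ccc(F)cc2)c2c1C=CC(C)(C)O2` carries a fluoro group on its outer ring. In a functional assay on HepG2 cells (Homo sapiens) for antiproliferative activity, read by MTT assay, with a stated time of 24 h (on this read-out higher numbers stand for weaker inhibition and lower numbers for stronger inhibition), compound 1 reaches only > 10000 nM, which is a limit of the assay and not a number (the limit of > 10000 nM in this assay, at which 1 of the 3 values shown sits). Compound 2 `CCN(CC)c1ccc(/C=C/C(=O)c2ccc(OC)c3c2OC(C)(C)C=C3)cc1` carries a diethylamino group in the same place, and in this assay compound 2 gives 590 nM; the change gives an at least 16-fold lower number from compound 1 to compound 2 (1.22 log units; beyond the scatter). Compound 3 `COc1ccc(C(=O)/C=C/c2ccc(N3CCCC3)cc2)c2c1C=CC(C)(C)O2` carries a pyrrolidin-1-yl group, and in this assay compound 3 gives 4740 nM, the higher of the two numbers measured. Its steps are an at least 2.1-fold lower number from compound 1 to compound 3 (0.32 log units; beyond the scatter) and an 8.0-fold higher number from compound 2 to compound 3 (0.90 log units; beyond the scatter).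

Compound 4 `COc1ccc(C(=O)/C=C/c2ccc(-n3ccnc3)cc2)c2c1C=CC(C)(C)O2` differs from compound 3 by one change: 1H-imidazol-1-yl in place of pyrrolidin-1-yl on an aromatic carbon. Both steps that reach compound 3 bear on this: an amine in place of fluoro lowered the number, yet the move from diethylamino to pyrrolidin-1-yl already raised it. The imidazol-1-yl group removes the dialkylamino pattern shared by compounds 2 and 3, so a further rise is expected, a 2.1-fold higher number from compound 3 to compound 4 (0.32 log units; beyond the scatter). Compound 4 is therefore expected to give 10000 nM, within 3000 nM to 30000 nM, quite possibly reaching the limit again.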

Compound 4, half-maximal inhibitory concentration: > 10000 nM
Compound 4 ended at the assay's limit; the forecaster's own chance of this, stated with the estimate: 45%; the middle value sits exactly at the limit.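

In this assay, having a ring at this position does not by itself keep a readable number: pyrrolidin-1-yl and 1H-imidazol-1-yl are both five-membered rings of 5 heavy atoms, yet exchanging the non-aromatic ring for the aromatic one gives an at least 2.1-fold higher number from compound 3 to compound 4 (0.32 log units; beyond the scatter). Measured against the open-chain diethylamino group, the change is larger, an at least 16-fold higher number from compound 2 to compound 4 (1.22 log units; beyond the scatter), so of the four groups shown, only diethylamino and pyrrolidin-1-yl give a number rather than a limit. Compound 1 and compound 4 both sit at a limit, so the step between them cannot be read and fluoro and 1H-imidazol-1-yl cannot be ranked: the limit of > 10000 nM in this assay, at which 2 of the 4 values shown sit.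

On these data alone, it remains open where dimethylamino or a six-membered ring such as piperidin-1-yl or morpholin-4-yl would fall. The compounds shown also cannot tell whether a longer chain on the nitrogen, such as dipropylamino, would give a lower number than compound 2.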